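A few compounds are considered here, and "the series" means these few. Any claim that something is new, unique, unknown or untested is made for them only; others in the source may bear on it.

Measured so far in a functional assay on A549 cells (Homo sapiens) for antiproliferative activity, read by MTT assay, with a stated time of 72 h; a lower number here means a stronger inhibitor, a higher number a weaker inhibitor:
- compound 1 `COc1cccc(N2C(=O)COc3ccc(-c4cccc(NS(=O)(=O)c5ccc(F)cc5)c4)cc32)c1`: > 40000 nM (a limit)
- compound 2 `O=C1COc2ccc(-c3cccc(NS(=O)(=O)c4ccc(F)cc4)c3)cc2N1c1ccc(Cl)cc1`: 31600 nM
- compound 3 `O=C1COc2ccc(-c3cccc(NS(=O)(=O)c4ccc(F)cc4)c3)cc2N1C1CC1`: > 40000 nM (a limit)

Compound 3 gives > 40000 nM, which is a limit of the assay and not a number. Most of the small set sits at this ceiling, as shown by the limit of > 40000 nM in this assay, at which 2 of the 3 values shown sit.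

The next compound is compound 4 `COc1ccc(N2C(=O)COc3ccc(-c4cccc(NS(=O)(=O)c5ccc(F)cc5)c4)cc32)cc1`, with 4-methoxyphenyl in place of cyclopropyl on the amide-type nitrogen in a ring: 4-methoxyphenyl in place of cyclopropyl on an amide-type nitrogen in a ring.

Three measured steps change the same nitrogen substituent. The swap of 3-methoxyphenyl for 4-chlorophenyl gives an at least 1.2-fold lower number from compound 1 to compound 2 (0.10 log units; that floor lies within the scatter). The swap of 4-chlorophenyl for cyclopropyl gives an at least 1.2-fold higher number from compound 2 to compound 3 (0.10 log units; that floor lies within the scatter). Both floors lie within the scatter. The swap of 3-methoxyphenyl for cyclopropyl gives a step that the two limits leave unreadable from compound 1 to compound 3, so its size cannot be read.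

None of these steps shows a change beyond the scatter, so no step beyond the scatter is expected in this assay, and no direction can be favoured. Compound 4 may well be reported only as a limit.

The expected change is a number no higher from compound 3 to compound 4 (the limit leaves the size open), an estimate that rests on the small steps above.

Compound 4 is estimated at 40000 nM, with an expected range from 20000 nM to 70000 nM.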

Compound 4, half-maximal inhibitory concentration: 38200 nM
The estimate for compound 4 lay 1.0-fold (0.02 log units) above the measured number, within the range that was stated.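

In this assay, going by these compounds alone, methoxy in place of chloro on an aromatic carbon gives a 1.2-fold higher number from compound 2 to compound 4 (0.08 log units; within the scatter), the only new step with a number at both ends, and it shows that these two para-free names of the group, 4-chlorophenyl and 4-methoxyphenyl, cannot be told apart at this nitrogen. The two other new steps rest on limits: 4-methoxyphenyl in place of cyclopropyl gives an at least 1.0-fold lower number from compound 3 to compound 4 (0.01 log units; that floor lies within the scatter), and 4-methoxyphenyl in place of 3-methoxyphenyl gives an at least 1.0-fold lower number from compound 1 to compound 4 (0.01 log units; that floor lies within the scatter), so neither shows a change beyond the scatter. Across the 4-chlorophenyl, 3-methoxyphenyl, 4-methoxyphenyl and cyclopropyl groups, changes on this amide-type nitrogen have so far moved no compound clearly away from the ceiling of the read-out: the limit of > 40000 nM in this assay, at which 2 of the 4 values shown sit.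

The compounds shown leave open whether a dimethylaminoethyl chain or a carboxylic acid on this nitrogen would lower the number beyond the scatter. Also open, going by these compounds, is whether a change elsewhere in the shared core, which is identical in all four compounds, would move the number more than any change at this nitrogen.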